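The source may report more compounds than this note shows. Statements on the series, on what has been measured and on what is new or still open speak of the compounds shown alone.

Measured so far:
compound 1, `CC/C(=C(/c1ccc(/C=C/C(=O)O)cc1)c1cc2ccccc2[nH]1)c1cccc(OC(F)(F)F)c1`, 282 nM
compound 2, `CC/C(=C(/c1ccc(/C=C/C(=O)O)cc1)c1cc2ccccc2[nH]1)c1ccc(C#N)cc1`, 278 nM

In a functional assay on MCF7 cells (Homo sapiens) for inhibition (on this read-out higher numbers stand for weaker inhibition and lower numbers for stronger inhibition), compound 1 and compound 2 stand together: the step of a 1.0-fold lower number from compound 1 to compound 2 (0.01 log units; within the scatter) lies within the scatter, so neither can be called the more or the less potent of the two. Compound 3, `CC/C(=C(/c1ccc(/C=C/C(=O)O)cc1)c1cc2ccccc2[nH]1)c1c(C)cccc1Cl`, has not been measured. It differs from compound 1 in one place: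
2-chloro-6-methylphenyl in place of 3-(trifluoromethoxy)phenyl on a double-bonded chain carbon bound to a double-bonded chain carbon and a saturated chain carbon
Going by the values given here, the only measured step that bears on this change is a 1.0-fold lower number from compound 1 to compound 2 (0.01 log units; within the scatter), where a different group entered at the same place, on a double-bonded chain carbon bound to a double-bonded chain carbon and a saturated chain carbon, and the number did not move beyond the scatter. The shared core and the rest of the molecule are untouched. On that basis no step beyond the scatter is expected in this assay for compound 3 in either direction, though a single step is a thin basis and the group entering here is of a new kind. Compound 3 is therefore expected to give about 300 nM, within 120 nM to 750 nM, which means an expected step of a 1.1-fold higher number from compound 1 to compound 3 (0.03 log units; within the scatter).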

Compound 3, half-maximal inhibitory concentration: 30 nM
The estimate for compound 3 lay 10-fold (1.00 log units) above the measured number; measured number outside the range, below it.
By their numbers in this assay, from the lowest: compound 3; then compounds 2 and 1 (each within the scatter of the next).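

In this assay, the earlier pair gave no sign that this position could move the number, but 2-chloro-6-methylphenyl in place of 3-(trifluoromethoxy)phenyl gives a 9.4-fold lower number from compound 1 to compound 3 (0.97 log units; beyond the scatter), and in place of 4-cyanophenyl it gives a 9.3-fold lower number from compound 2 to compound 3 (0.97 log units; beyond the scatter). The place on the double-bonded chain carbon is therefore not indifferent to the group it carries, and compound 3 has the lowest number of the three, with steps to both others beyond the scatter. Nothing measured here accounts for what sets 2-chloro-6-methylphenyl apart from the other two groups.

The compounds shown leave open whether the chlorine, the methyl or only the two together bring this step, as the chlorine and the methyl appear here only as a pair on one ring. They also leave open how an amine or a cyclohexyl group would behave at this place, and whether the step would persist with an amide in place of the carboxylic acid.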